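Trimethoxyphenyl in place of methoxyphenyl on the dimethylbenzothiazole amide

A few compounds are considered here, and "the series" means these few. Any claim that something is new, unique, unknown or untested is made for them only; others in the source may bear on it.

Measured compounds:
- compound 1 `COc1cc(-c2cc(C(=O)Nc3nc4ccc(F)cc4s3)nc3cc(-c4ccccc4)nn23)cc(OC)c1OC`: 27500 nM
- compound 2 `COc1ccc2nc(NC(=O)c3cc(-c4cc(OC)c(OC)c(OC)c4)n4nc(-c5ccccc5)cc4n3)sc2c1`: 2950 nM
- compound 3 `COc1ccc(-c2cc(C(=O)Nc3nc4cc(C)c(C)cc4s3)nc3cc(-c4ccccc4)nn23)cc1`: 19700 nM

In a functional assay on MCF7 cells (Homo sapiens) for cytotoxicity, read by MTT assay, with a stated time of 48 h (a lower number here means a stronger inhibitor, a higher number a weaker inhibitor), compound 3 stands second highest of the three numbers. Its nearest neighbour is compound 1, within the scatter of it; compound 2 lies furthest away, with a number beyond the scatter lower than that of compound 3.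

Compound 4 `COc1cc(-c2cc(C(=O)Nc3nc4cc(C)c(C)cc4s3)nc3cc(-c4ccccc4)nn23)cc(OC)c1OC` arises from compound 3 by the change (3,4,5-trimethoxyphenyl in place of 4-methoxyphenyl on an aromatic carbon), on the shared core. Compound 1 and compound 2 already carry the 3,4,5-trimethoxyphenyl group. Within the data shown here, the only measured single step, a 9.3-fold lower number from compound 1 to compound 2 (0.97 log units; beyond the scatter), concerns a different position and does not bear on this change. Among the measured compounds shown here, no measured pair isolates the swap of 4-methoxyphenyl for 3,4,5-trimethoxyphenyl; the nearest guide is that compound 1, which carries the entering group, sits within the scatter of compound 3 in this assay.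

No step beyond the scatter is therefore expected. The expected step is a 1.0-fold higher number from compound 3 to compound 4 (0.01 log units; within the scatter). Compound 4 is estimated at 20000 nM, within a range from 6000 nM to 60000 nM.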

Compound 4, half-maximal inhibitory concentration: 2290 nM
For compound 4 the middle estimate is 8.7-fold (0.94 log units) above the measured one, and the stated range ends above it.
By their numbers in this assay, from the lowest: compounds 4 and 2 (each within the scatter of the next); then compounds 3 and 1 (each within the scatter of the next).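

In this assay, among these compounds, the change at this aromatic carbon is isolated for the first time, with the 5,6-dimethyl-1,3-benzothiazol-2-yl amide held fixed, and it gives an 8.6-fold lower number from compound 3 to compound 4 (0.93 log units; beyond the scatter). With 3,4,5-trimethoxyphenyl held fixed, changes on the amide-type nitrogen give a 1.3-fold lower number from compound 2 to compound 4 (0.11 log units; within the scatter) and a 12-fold lower number from compound 1 to compound 4 (1.08 log units; beyond the scatter), so 5,6-dimethyl-1,3-benzothiazol-2-yl and 6-methoxy-1,3-benzothiazol-2-yl stand level while 6-fluoro-1,3-benzothiazol-2-yl falls behind both. No evidence on the cause of these steps is available.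

Going by these compounds, whether the same swap gives a step of this size with 6-fluoro-1,3-benzothiazol-2-yl or 6-methoxy-1,3-benzothiazol-2-yl on the amide remains open. Also open, on these data alone, is how a phenyl ring carrying two methoxy groups, an amine or a carboxylic acid would compare at this aromatic carbon.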